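This account rests on a few compounds, and the source may have more. Where it says the series, first, only, none or still open, it means among the compounds named here.

Compound 1, with the structure `Cc1ccc2nc(-c3ccc(NCc4cn(Cc5cc(=O)oc6cc(O)ccc56)nn4)cc3)sc2c1`, gives 10500 nM in a functional assay on CFPAC-1 cells (Homo sapiens) for inhibition, read by MTT assay, with a stated time of 72 h; a higher number here means a weaker inhibitor, a lower number a stronger inhibitor. Compound 2, with the structure `Cc1ccc2c(Cn3cc(CNc4ccc(-c5nc6ccc(C)cc6s5)cc4)nn3)cc(=O)oc2c1`, differs from it by a (methyl in place of hydroxy on an aromatic carbon); in this assay compound 2 gives 34900 nM, so the change made a 3.3-fold higher number from compound 1 to compound 2 (0.52 log units; beyond the scatter). Compound 3, with the structure `O=c1cc(Cn2cc(-n3ccc4cc(I)ccc43)nn2)c2ccc(O)cc2o1`, belongs to a different core, and the difference between the core of compound 1 and the core of compound 3 is not broken down here. In this assay compound 3 gives 29900 nM, which lies close to the value of compound 2 and clearly higher than that of compound 1. Compound 4, with the structure `Cc1ccc2c(Cn3cc(-n4ccc5cc(I)ccc54)nn3)cc(=O)oc2c1`, has not yet been measured; it differs from compound 3 by a (methyl in place of hydroxy on an aromatic carbon), the same change, at the same kind of place, that separates compound 1 from compound 2. Going by the values given here, since the only measured example of this change is the step of a 3.3-fold higher number from compound 1 to compound 2 (0.52 log units; beyond the scatter) from compound 1 to compound 2, compound 4 is expected to show a step of a 2.8-fold higher number from compound 3 to compound 4 (0.45 log units; beyond the scatter) in this assay, with the caution that it rests on a single pair and on a different core. Compound 4 is therefore estimated at 85000 nM, within a range from 35000 nM to 200000 nM.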

Compound 4, half-maximal inhibitory concentration: 41700 nM
The estimate for compound 4 lay 2.0-fold (0.31 log units) above the measured number, and the stated range covers the measured number.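

In this assay, replacing hydroxy with methyl on the core of compound 3 gave a 1.4-fold higher number from compound 3 to compound 4 (0.14 log units; within the scatter), so this step alone does not separate the two compounds. Set beside the earlier step on the core of compound 1, the change does not differ measurably between the two cores: the same change on two cores in this assay, a 3.3-fold higher number (0.52 log units; beyond the scatter) from compound 1 to compound 2 and a 1.4-fold higher number (0.14 log units; within the scatter) from compound 3 to compound 4, 2.4-fold (0.38 log units) apart, within the scatter of two such steps. The two cores are therefore compatible with a shared effect of the change, but two pairs cannot establish that it transfers, and with one step beyond the scatter and the other within it, they fix neither its size nor even whether it is a real effect on the core of compound 3.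

The compounds shown leave open what an amine, a methoxy group or a fluorine atom would give on the same aromatic carbon, since hydroxy and methyl are the only groups compared there. Going by these compounds, it also remains open whether the change would behave in the same way on any further core.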